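Benzyl-ring variation on the shared core

The source may report more compounds than this note shows. Statements on the series, on what has been measured and on what is new or still open speak of the compounds shown alone.

Measured so far in an assay on isolated protein for inhibition of alpha-ketoglutarate-dependent dioxygenase alkB homolog 3 (Homo sapiens), read by polymerase chain reaction, with a stated time of 1 h; on this read-out higher numbers stand for weaker inhibition and lower numbers for stronger inhibition:
compound 1 `COc1ccc(Cc2c(C)[nH]n(-c3nc4ccccc4[nH]3)c2=O)cc1` gives 630 nM.
compound 2 `Cc1[nH]n(-c2nc3ccccc3[nH]2)c(=O)c1Cc1ccccc1Cl` gives only a limit of the assay, > 10000 nM.
compound 3 `Cc1[nH]n(-c2nc3ccccc3[nH]2)c(=O)c1Cc1cccc(Cl)c1` gives 540 nM.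

Compound 1 stands highest of the two numbers shown, though a 1.2-fold lower number from compound 1 to compound 3 (0.07 log units; within the scatter) lies within the scatter. The remaining value is a limit of the assay (the limit of > 10000 nM in this assay, at which 1 of the 3 values shown sits). Compound 4 `Cc1[nH]n(-c2nc3ccccc3[nH]2)c(=O)c1Cc1ccc(-c2ccccc2)cc1` differs from compound 1 by phenyl in place of methoxy on an aromatic carbon. The measured steps move or swap the substituent on the benzyl ring: an at least 15-fold higher number from compound 1 to compound 2 (1.20 log units; beyond the scatter) and an at least 18-fold lower number from compound 2 to compound 3 (1.26 log units; beyond the scatter) are both large, while the step to the 3-chlorophenyl analogue is flat. Within the data shown here, no measured step puts a larger group at this place, so the expectation is loose. Compound 4 is estimated at 1000 nM (range 250 nM to 6000 nM), an expected 1.6-fold higher number from compound 1 to compound 4 (0.20 log units; within the scatter).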

Compound 4, half-maximal inhibitory concentration: 720 nM
For compound 4 the middle estimate is 1.4-fold (0.14 log units) above the measured one; the range from low to high includes it.
By their numbers in this assay, from the lowest: compounds 3, 1 and 4 (each within the scatter of the next). At a limit, above all of these: compound 2.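

Phenyl in place of methoxy, para to a large group, gives a 1.1-fold higher number from compound 1 to compound 4 (0.06 log units; within the scatter), so this place on the benzyl ring accepts 6 heavy atoms and a six-membered aromatic ring where methoxy held 2 heavy atoms. The hydrogen-bond acceptor of methoxy can also leave without a change beyond the scatter. Nothing measured here accounts for this flat step.

Still open, on these data alone, is how an amine, a carboxylic acid or a longer chain would read at this place. As far as these compounds go, a second aromatic ring with its own substituents also remains open.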